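Chalcone Cytotoxicity: From Compound 3 to Compound 4

The source may report more compounds than this note shows. Statements on the series, on what has been measured and on what is new or still open speak of the compounds shown alone.

Measured so far:
compound 1, `COc1cccc(/C=C/C(=O)c2c(OC)cc(OC)cc2OC)c1`, gives 5900 nM
compound 2, `COc1cc(OC)c(C(=O)/C=C/c2ccc(Cl)cc2)c(OC)c1`, gives 6500 nM
compound 3, `COc1cc(OC)c(C(=O)/C=C/c2ccc(Br)cc2)c(OC)c1`, gives 8300 nM

These three numbers come from a functional assay on RL cells (Homo sapiens) for cytotoxicity, with a stated time of 48 h; on this read-out higher numbers stand for weaker inhibition and lower numbers for stronger inhibition. Compound 3 sits at the top of the three numbers, but a 1.4-fold higher number from compound 1 to compound 3 (0.15 log units; within the scatter) and a 1.3-fold higher number from compound 2 to compound 3 (0.11 log units; within the scatter) both lie within the scatter, so the three compounds cannot be told apart on this read-out. For the measured compounds named here, the only other measured step, a 1.1-fold higher number from compound 1 to compound 2 (0.04 log units; within the scatter), is also within the scatter.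

Compound 4, `COc1cc(OC)c(C(=O)/C=C/c2ccccc2SC)c(OC)c1`, has not yet been measured. It differs from compound 3 by 2-(methylsulfanyl)phenyl in place of 4-bromophenyl on a double-bonded chain carbon bound to a double-bonded chain carbon. The measured steps all exchange the group on the double-bonded chain carbon, or exchange one halogen for another on an aromatic carbon, and none moved the number beyond the scatter. Going by the values given here, no measured step introduces a methylsulfanyl group, so the bearing of those steps is indirect. A step of no size beyond the scatter is therefore expected in this assay.

Compound 4 is expected to give 7000 nM, with a range from 2500 nM to 20000 nM. This expected step is a 1.2-fold lower number from compound 3 to compound 4 (0.07 log units; within the scatter).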

Compound 4, half-maximal inhibitory concentration: 8300 nM
Beside the measured number, compound 4's estimate is 1.2-fold (0.07 log units) below it, and the stated range covers the measured number.
By their numbers in this assay, from the lowest: compounds 1, 2, 3 and 4 (each within the scatter of the next).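

For the compounds shown here, putting 2-(methylsulfanyl)phenyl in place of 4-bromophenyl on a double-bonded chain carbon bound to a double-bonded chain carbon introduces a sulfur-bearing group that none of the earlier compounds carried, and in this assay this gives no change at the digits printed from compound 3 to compound 4 (within the scatter). The comparisons with the other two groups agree, with a 1.3-fold higher number from compound 2 to compound 4 (0.11 log units; within the scatter) and a 1.4-fold higher number from compound 1 to compound 4 (0.15 log units; within the scatter), so the four groups at this place cannot be told apart on this read-out. No supporting measurement is available to explain this flat result.

Still open, from the compounds shown here alone, is whether a phenyl ring carrying an amine or a carboxylic acid at this place would move the number beyond the scatter. Also open, going by these compounds, is whether a longer chain in place of the phenyl ring would do so.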